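A few compounds are considered here, and "the series" means these few. Any claim that something is new, unique, unknown or untested is made for them only; others in the source may bear on it.

Measured so far in this series:

Compound 1 `CCCCN(CC)c1cc(C)nc2c1NCCN2c1ccc(C#N)cc1C`: 3.5 nM
Compound 2 `CCCCN(CC)c1nc(C)nc2c1NC(=O)CN2c1ccc(C#N)cc1C`: 573 nM
Compound 3 `CCCCN(CC)c1cc(C)nc2c1NCCN2c1ccc(C(C)=O)cc1C`: 8.2 nM

All three values come from an assay on frontal cortex for displacement of a labelled ligand from corticotropin-releasing factor receptor 1 (Rattus norvegicus); on this read-out higher numbers stand for weaker inhibition and lower numbers for stronger inhibition. Compound 1 and compound 3 share one core; compound 2 carries a different core, and the difference between the two cores is not broken down here. Within this assay compound 2 gives the highest number of the three, 573 nM, set against 8.2 nM for compound 3 and 3.5 nM for compound 1.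

Among the measured compounds shown here, the one change that is measured on its own is the one between compound 1 and compound 3: acetyl in place of cyano on an aromatic carbon. In this assay it made a modest step, a 2.3-fold higher number from compound 1 to compound 3 (0.37 log units; beyond the scatter).

Compound 4 `CCCCN(CC)c1nc(C)nc2c1NC(=O)CN2c1ccc(C(C)=O)cc1C` has not yet been measured in this assay. It stands to compound 2 as compound 3 stands to compound 1: the change is acetyl in place of cyano on an aromatic carbon, the same change at the same place as in the measured pair, made on the core of compound 2 instead of the core of compound 1.

The step is expected to be a 2.3-fold higher number from compound 2 to compound 4 (0.36 log units; beyond the scatter), because a 2.3-fold higher number from compound 1 to compound 3 (0.37 log units; beyond the scatter) was found for the same change on the other core, and nothing measured here argues for a different direction. Compound 4 is therefore estimated at 1300 nM in this assay, expected to fall between 450 nM and 4000 nM; the wide range reflects that the transfer rests on a single measured pair.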

Compound 4, half-maximal inhibitory concentration: 713 nM
Beside the measured number, compound 4's estimate is 1.8-fold (0.26 log units) above it, within the range that was stated.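

In this assay, acetyl in place of cyano on the core of compound 2 gives a 1.2-fold higher number from compound 2 to compound 4 (0.09 log units; within the scatter), so on this core the two compounds cannot be told apart. Set beside the step on the core of compound 1, this result gives no readable difference between the two cores: the same change on two cores in this assay, a 2.3-fold higher number (0.37 log units; beyond the scatter) from compound 1 to compound 3 and a 1.2-fold higher number (0.09 log units; within the scatter) from compound 2 to compound 4, 1.9-fold (0.27 log units) apart, within the scatter of two such steps. Among the compounds shown here, the change can therefore be carried between these two cores without a measurable difference in its step, but this rests on only two matched pairs and does not show that the step is identical on both cores or that it would hold on any other core.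

The compounds shown leave open whether the agreement extends to other groups at this aromatic carbon, such as a carboxylic acid, an amine or a longer acyl chain in place of cyano, when each is carried between the two cores. They also leave open which of the structural differences between the core of compound 1 and the core of compound 2 accounts for the gap in values between the two cores, since those differences are not separated in any single measured pair.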